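Terminal amine variation on the ether chain: working notes

The source may report more compounds than this note shows. Statements on the series, on what has been measured and on what is new or still open speak of the compounds shown alone.

Measured so far in an assay on isolated protein (Cavia porcellus) with Sigma non-opioid intracellular receptor 1 (Homo sapiens) as the target, read by radioligand binding; a lower number here means a stronger inhibitor, a higher number a weaker inhibitor:
compound 1 `CN(C)CCCCCCCOc1ccc2oc(-c3ccccc3)cc(=O)c2c1` — 165 nM
compound 2 `O=c1cc(-c2ccccc2)oc2ccc(OCCCCCCN3CCNC(CCO)C3)cc12` — 63 nM

Compound 2 holds the lowest of the two numbers in this assay; its nearest neighbour is compound 1, and the gap, a 2.6-fold lower number from compound 1 to compound 2 (0.42 log units; beyond the scatter), is modest but beyond the scatter. The two compounds share the same core and chain and differ only at the chain terminus.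

Compound 3 `NCCCCCCOc1ccc2oc(-c3ccccc3)cc(=O)c2c1` has not been measured. Its difference from compound 2 is amino in place of 3-(2-hydroxyethyl)piperazin-1-yl on a saturated chain carbon, six bonds along the chain from an oxygen on an aromatic ring. For the measured compounds named here, the one measured step that bears on this position runs the other way: a 2.6-fold lower number from compound 1 to compound 2 (0.42 log units; beyond the scatter) shows that replacing the small dimethylamino terminus with the larger hydroxyethyl-piperazinyl group lowered the number. Going by the values given here, compound 3 carries the smallest terminus of the three, so the expectation is a step upward in this assay, probably beyond the scatter and plausibly past compound 1 as well, though no measured pair tests a primary amine directly. The expected step is a 6.3-fold higher number from compound 2 to compound 3 (0.80 log units; beyond the scatter). For compound 3 the estimate in this assay is 400 nM, with a range from 100 nM to 1600 nM.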

Compound 3, half-maximal inhibitory concentration: 2100 nM
Compound 3: the middle estimate sits 5.3-fold (0.72 log units) below what was measured; measured number above the stated range.
By their numbers in this assay, from the lowest: compound 2; then compound 1; then compound 3.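

Moving to amino at the chain terminus shows that this position is far more sensitive in this assay than the earlier 2.6-fold lower number from compound 1 to compound 2 (0.42 log units; beyond the scatter) suggested: the change gives a 33-fold higher number from compound 2 to compound 3 (1.52 log units; beyond the scatter), and the comparison with the dimethylamino-bearing terminus gives a 13-fold higher number from compound 1 to compound 3 (1.10 log units; beyond the scatter). Both steps are large, so most of the spread among the three compounds lies between the unsubstituted amino terminus and the two substituted ones, not between those two; across these three compounds, the number rises as the terminus gets smaller, with none going against that order. Nothing available explains why the amino terminus falls so far behind the other two.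

The compounds shown leave open whether substitution on the terminal nitrogen alone recovers most of the lost ground, which a methylamino terminus on the same chain would test directly. They also leave open how much of compound 2's standing comes from the 2-hydroxyethyl arm and how much from the ring, which an unsubstituted piperazin-1-yl or a piperidin-1-yl terminus would separate.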